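The source may report more compounds than this note shows. Statements on the series, on what has been measured and on what is new or still open speak of the compounds shown alone.

Values in an ADME assay on Vero cells (Chlorocebus sabaeus) for cytotoxicity, read by MTT assay, with a stated time of 72 h; a higher number here means a weaker inhibitor, a lower number a stronger inhibitor:
Compound 1 `COc1ccc(CNc2ncnc(-c3ccco3)c2N)cc1`: "not determined" (no result reported)
Compound 2 `CCNc1c(NCc2ccc(OC)cc2)ncnc1-c1ccco1`: "not determined" (no result reported)
Compound 3 `COc1ccc(CNc2nc([N+](=O)[O-])nc(-c3ccco3)c2NC=O)cc1`: > 40 ug/mL

Of these three compounds, only compound 3 has a reported result, and that result is a limit of the assay rather than a number. Compound 3 stands at the limit of > 40 ug/mL in this assay, at which 1 of the 3 values shown sits. Among the compounds with values here, no pair of measured compounds gives a step to compare, so the data offer no measured size for any structural change.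

The next compound is compound 4 `CCc1nc(NCc2ccc(OC)cc2)c(NC=O)c(-c2ccco2)n1`. It keeps the rest of compound 3 but carries ethyl in place of nitro on an aromatic carbon, between two ring nitrogen atoms and para to a formylamino group (ethyl in place of nitro on an aromatic carbon).

With only the limit of compound 3 to go on, no change beyond the usual scatter is expected in this assay, and no direction can be favoured. The estimated move is a step that the limit leaves unreadable from compound 3 to compound 4. For compound 4 the expected value is 45 ug/mL. The estimated range for compound 4 runs from 20 ug/mL to 100 ug/mL.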

Compound 4, half-maximal inhibitory concentration: > 40 ug/mL
Compound 4 gave a limit, no number; the forecaster's own chance of this, stated with the estimate: 70%; the middle value is on the limit's open side.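

In this assay no step can be read from compound 3 to compound 4, since both results are limits of the assay and not numbers: the limit of > 40 ug/mL in this assay, at which 2 of the 4 values shown sit.

The compounds shown leave open whether ethyl in place of nitro changes this read-out at all, and in which direction.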